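Swapping the amine on the carbonyl of compound 3

The compounds below may be only part of what the source reports. "The series", "measured", "known", "first", "only" and "open" are said of these compounds alone.

Compound 3 `CN(C)C(=O)c1ccncc1Nc1cc(-c2ccc3ccn(C)c3c2)c2nccnc2c1` gives the highest of three numbers in an assay for inhibition of 6-phosphofructo-2-kinase/fructose-2,6-bisphosphatase 3 (Homo sapiens), read by ADP-Glo, with a stated time of 2 h (on this read-out lower numbers stand for stronger inhibition and higher numbers for weaker inhibition), where compound 3 reads 499 nM. Its two neighbours are compound 1 `Cn1ccc2ccc(-c3cc(Nc4ccccc4S(=O)(=O)N4CCOCC4)cc4nccnc34)cc21` with 36 nM and compound 2 `CN1CCC(NS(=O)(=O)c2ccccc2Nc2cc(-c3ccc4ccn(C)c4c3)c3nccnc3c2)C1` with 33 nM; both sit well apart from compound 3, as the gaps are beyond the scatter. Compound 4 `CN1CC(NC(=O)c2ccncc2Nc2cc(-c3ccc4ccn(C)c4c3)c3nccnc3c2)CCC1=O` differs from compound 3 in one place: (1-methyl-6-oxopiperidin-3-yl)amino in place of dimethylamino on a carbonyl carbon. For the measured compounds named here, the one measured step that resembles this is the exchange of the amine on a sulfonyl sulfur, a 1.1-fold lower number from compound 1 to compound 2 (0.04 log units; within the scatter), which stayed within the scatter. That step sits on a sulfonyl rather than a carbonyl, so it is only a loose guide, and nothing measured here shows a ring-bearing amine on this carbonyl. On that basis the step in this assay is expected to be small, a 1.2-fold lower number from compound 3 to compound 4 (0.10 log units; within the scatter), in no firm direction. Compound 4 is therefore estimated at 400 nM, within a range from 150 nM to 1200 nM.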

Compound 4, half-maximal inhibitory concentration: 116 nM
The estimate for compound 4 lay 3.4-fold (0.54 log units) above the measured number; measured number outside the range, below it.
By their numbers in this assay, from the lowest: compounds 2 and 1 (each within the scatter of the next); then compound 4; then compound 3.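

In this assay the amine on this carbonyl carbon does affect the read-out: (1-methyl-6-oxopiperidin-3-yl)amino in place of dimethylamino gives a 4.3-fold lower number from compound 3 to compound 4 (0.63 log units; beyond the scatter), a modest step. The exchange of one amine for another on a sulfonyl sulfur, a 1.1-fold lower number from compound 1 to compound 2 (0.04 log units; within the scatter), had stayed within the scatter, so that step gave no sign of this movement on the carbonyl. The entering group brings a six-membered non-aromatic ring, a hydrogen-bond donor and a hydrogen-bond acceptor all at once, and nothing available here explains the step.

The compounds shown do not separate these features from one another. From the compounds shown here alone, it remains open whether plain methylamino on the same carbonyl carbon, or piperidin-3-ylamino without the ring carbonyl and the methyl, would give a step of similar size.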